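This account rests on a few compounds, and the source may have more. Where it says the series, first, only, none or still open, it means among the compounds named here.

Measured so far, in an assay for inhibition of ribosomal protein S6 kinase beta-1 variant D18H,T412E (Homo sapiens), read by a luciferase reporter and chemiluminescence, with a stated time of 3 h; on this read-out higher numbers stand for weaker inhibition and lower numbers for stronger inhibition: compound 1 `CCCc1n[nH]c2ncnc(N3CCN(c4cc(Cl)ccc4C)CC3)c12` gives 6 nM; compound 2 `Cc1ccc(Cl)cc1N1CCN(c2ncnc3[nH]nc(Br)c23)CC1` gives 7 nM.

Compound 2 has the higher of these two numbers, but the gap to compound 1 is small: a 1.2-fold higher number from compound 1 to compound 2 (0.07 log units; within the scatter), which marks a swap of propyl for bromo on an aromatic carbon of the shared core. Two numbers this close cannot be told apart.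

Compound 3 `Cc1ccc(Cl)cc1N1CCN(c2ncnc3[nH]nc(C(F)(F)F)c23)CC1` carries the same core and the same piperazine-linked aryl group. It differs from compound 2 only in one place: trifluoromethyl in place of bromo on an aromatic carbon. Among the compounds with values here, the one measured step that bears on this position, from compound 1 to compound 2, exchanged groups of quite different kind at this same carbon and yet stayed within the scatter. On that basis the substituent at this carbon seems to matter little, and no step beyond the scatter is expected in this assay. The estimate for compound 3 is therefore 8 nM (range 3 nM to 20 nM), which is expected to correspond to a 1.1-fold higher number from compound 2 to compound 3 (0.06 log units; within the scatter).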

Compound 3, half-maximal inhibitory concentration: 29 nM
For compound 3 the middle estimate is 3.6-fold (0.56 log units) below the measured one; measured number above the stated range.
By their numbers in this assay, from the lowest: compounds 1 and 2 (each within the scatter of the next); then compound 3.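

This carbon of the shared core does not accept every group equally in this assay: trifluoromethyl brings weaker inhibition than either earlier group, with a 4.1-fold higher number from compound 2 to compound 3 (0.62 log units; beyond the scatter) and a 4.8-fold higher number from compound 1 to compound 3 (0.68 log units; beyond the scatter). Both steps are modest but lie beyond the scatter, so the earlier match between bromo and propyl does not extend to all groups at this position. Nothing available here explains why trifluoromethyl stands apart from these two groups.

The compounds shown leave open how other groups at this carbon would compare, such as an amine, a carboxylic acid or a chain longer than propyl. They also leave open whether trifluoromethyl in place of bromo would give a similar step with a different aryl group on the piperazine, as all three compounds carry the same one.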